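Hydroxyphenyl-substituted pyridines against human topoisomerase 1

The source may report more compounds than this note shows. Statements on the series, on what has been measured and on what is new or still open speak of the compounds shown alone.

Measured so far:
compound 1 `Oc1cccc(-c2cc(-c3cccc(O)c3)nc(-c3ccccc3O)c2)c1` gives 1.9%
compound 2 `Oc1ccccc1-c1cc(-c2ccccc2O)nc(-c2ccccc2O)c1` gives 0%
compound 3 `Oc1ccc(-c2cc(-c3cccc(O)c3)cc(-c3cccc(O)c3)n2)cc1` gives 0%

All three were tested in an assay on isolated protein for inhibition of DNA topoisomerase 1 (Homo sapiens), with a stated time of 30 min, tested at 100 uM; a higher number here means more inhibition at the concentration tested (going by the name of the read-out), a lower number less inhibition. Compound 1 and compound 3 differ in one place, (4-hydroxyphenyl in place of 2-hydroxyphenyl on an aromatic carbon), and the step of a number 1.9 percentage points lower from compound 1 to compound 3 (within the scatter) lies within the scatter. Compound 2 stands at the same digits as compound 3, and compound 1 lies within the scatter of both, so none of the three can be set apart from the others. The difference between the cores of compound 1 and compound 2 is not broken down here.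

Compound 4 `Oc1ccc(-c2cc(-c3ccccc3O)cc(-c3ccccc3O)n2)cc1` is not yet measured. It differs from compound 2 by 4-hydroxyphenyl in place of 2-hydroxyphenyl on an aromatic carbon. This is the same kind of change as that from compound 1 to compound 3, though not the same: there the place is meta to two 3-hydroxyphenyl groups, here it is meta to two 2-hydroxyphenyl groups. The step from compound 2 to compound 4 is expected to be a number 1 percentage points higher from compound 2 to compound 4 (within the scatter), beside the earlier one, because a number 1.9 percentage points lower from compound 1 to compound 3 (within the scatter) was within the scatter and because all three measured values sit near the bottom of the read-out, compound 2 giving 0%. Compound 4 is therefore estimated at 1%, with a range expected from 0% to 10%.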

Compound 4, a percentage reported as inhibition, at one concentration (the size of the read-out at that concentration, not a potency): 0.3%
The estimate for compound 4 lay 0.7 percentage points above the measured number, and the stated range covers the measured number.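

In this assay the change to 4-hydroxyphenyl in place of 2-hydroxyphenyl, on the aromatic carbon next to the ring nitrogen, gives a number 0.3 percentage points higher from compound 2 to compound 4 (within the scatter) and leaves compound 4 indistinguishable from compound 2. Set beside the earlier case, the change reads the same on both cores: the same change on two cores in this assay, a number 1.9 percentage points lower (within the scatter) from compound 1 to compound 3 and a number 0.3 percentage points higher (within the scatter) from compound 2 to compound 4, 2.2 percentage points apart, within the scatter of two such steps. Going by these compounds alone, this shows only that, on these two cores, the change produces no step that can be told from the scatter; all four compounds sit near the bottom of the read-out at the single concentration tested, and the agreement between the two steps is an agreement between very small numbers, so it does not show that the change would carry over unaltered to a core with clear inhibition, where a real step could appear.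

The compounds shown carry hydroxyphenyl groups and nothing else on the shared core, and it remains open whether any group of another kind would lift the read-out clear of the scatter. An amine or a carboxylic acid on one of these rings, or a longer chain ending in an amine in place of a hydroxyl, would be a test of that question.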